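A few compounds are considered here, and "the series" means these few. Any claim that something is new, unique, unknown or untested is made for them only; others in the source may bear on it.

Compound 1 `Cc1nc(C(NC(=O)C(=O)Nc2ccc(F)cc2F)C2CCCCN2)sc1CO`: in an ADME assay on MT2 cells (Homo sapiens) for cytotoxicity, read by XTT assay, with a stated time of 4 days (a lower number here means that less compound is tolerated, a higher number that more compound is tolerated), compound 1 gives > 110000 nM, a limit of the assay rather than a number.
Compound 2 `Cc1nc(C(NC(=O)C(=O)Nc2ccc(Cl)cc2)C2CCCCN2C)sc1CCO`: in this assay compound 2 gives 88000 nM.
Compound 3 `Cc1nc(C(NC(=O)C(=O)Nc2ccc(F)cc2F)C2CCCCN2)sc1CCO`: in this assay compound 3 gives > 105000 nM, again a limit of the assay.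

Compound 1 therefore stands only at a limit, and two of the three values shown are limits, at the limit of > 110000 nM in this assay, at which 1 of the 3 values shown sits, and at the limit of > 105000 nM in this assay, at which 1 of the 3 values shown sits. Among the measured compounds shown here, the one change measured here, a step that the two limits leave unreadable from compound 1 to compound 3, cannot be sized for that reason. Compound 4 `Cc1nc(C(NC(=O)C(=O)Nc2ccc(C(F)(F)F)cc2)C2CCCCN2)sc1CO` is still to be measured; it differs from compound 1 as follows (4-(trifluoromethyl)phenyl in place of 2,4-difluorophenyl on an amide-type nitrogen). For the measured compounds named here, no measured pair changes only the aryl group on that amide nitrogen, and compound 2 differs from compound 1 in several places at once, so only its single value speaks, and it too sits close to the limits. Nothing in these numbers points to a readable step in either direction in this assay, so the expected change is an at least 1.1-fold lower number from compound 1 to compound 4 (0.04 log units; that floor lies within the scatter), within the scatter. Compound 4 is thus expected to give about 100000 nM, in a range from 40000 nM to 250000 nM, quite possibly reported only as a limit.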

Compound 4, half-maximal cytotoxic concentration: > 75500 nM
Compound 4: no number, only a limit; the forecaster's own chance of this, stated with the estimate: 65%; the middle value does not contradict the limit.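

The step from compound 1 to compound 4 cannot be read: in this assay, each of the two compounds is reported only as a limit, not as a number. The compounds shown leave open whether replacing 2,4-difluorophenyl with 4-(trifluoromethyl)phenyl changes cytotoxicity at all.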